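Cyclohexyl to Hydroxy Chain: Cytotoxicity Outlook for Compound 3

The compounds below may be only part of what the source reports. "The series", "measured", "known", "first", "only" and "open" are said of these compounds alone.

Compound 1 `O=C(Nc1ccc(NC2CCCCC2)cc1Cl)c1cc(Cl)ccc1O`: 68300 nM
Compound 2 `CN(C)c1ccc(CNc2ccc(NC(=O)c3cc(Cl)ccc3O)c(Cl)c2)cc1`: 24500 nM

In an ADME assay on A549 cells (Homo sapiens) for cytotoxicity, read by resazurin assay, with a stated time of 48 h (a lower number here means that less compound is tolerated, a higher number that more compound is tolerated), compound 1 gives 68300 nM, the higher of the two numbers measured, and compound 2 gives 24500 nM, a difference beyond the scatter. Among the measured compounds shown here, no single-change step between measured compounds is known, so the effect of the change to compound 3 `CC(C)(CCO)Nc1ccc(NC(=O)c2cc(Cl)ccc2O)c(Cl)c1`, (3-hydroxy-1,1-dimethylpropyl in place of cyclohexyl on a nitrogen on an aromatic ring), must be judged without precedent. The step of a 1.0-fold higher number from compound 1 to compound 3 (0.01 log units; within the scatter) is expected to be small, no more than the scatter, in either direction. Compound 3 is therefore estimated at 70000 nM, between 30000 nM and 160000 nM.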

Compound 3, half-maximal cytotoxic concentration: 170000 nM
Estimate against measurement, compound 3: 2.4-fold (0.39 log units) below, and the stated range ends below it.
By their numbers in this assay, from the lowest: compound 2; then compound 1; then compound 3.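

In this assay, placing 3-hydroxy-1,1-dimethylpropyl in place of cyclohexyl on a nitrogen on an aromatic ring gives a 2.5-fold higher number from compound 1 to compound 3 (0.40 log units; beyond the scatter), so the group at this position can shift how much compound the cells tolerate. The new group has as many heavy atoms as cyclohexyl, but no ring, and it adds a hydrogen-bond donor and acceptor. No available measurement explains the rise.

This one step changes the ring and the hydroxy group together, and the compounds shown cannot separate them. A 1,1-dimethylpropyl chain without the hydroxy group, or a cyclohexyl ring carrying one, remains to be compared.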